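The source may report more compounds than this note shows. Statements on the series, on what has been measured and on what is new or still open speak of the compounds shown alone.

The series shares one core, seen in compound 1 `COc1ncc(-c2nc(C(F)(F)F)sc2N2CCN(C(=O)Cn3cnc4cccnc43)[C@H](C)C2)cn1`, compound 2 `CCOc1ncc(-c2nc(C(F)(F)F)sc2N2CCN(C(=O)Cn3cnc4ccccc43)[C@H](C)C2)cn1` and compound 3 `COc1ncc(-c2nc(C(F)(F)F)sc2N2CCN(C(=O)Cn3nc(C)nc3C)[C@H](C)C2)cn1`. In an assay on blood for inhibition of C-X-C chemokine receptor type 3 (Homo sapiens), with a stated time of 30 min (a higher number here means a weaker inhibitor, a lower number a stronger inhibitor), compound 1 gives 158 nM, compound 2 gives 192 nM and compound 3 gives 1040 nM. Among the compounds with values here, compound 3 thus stands highest of the three, its gaps to compound 2 and to compound 1 both beyond the scatter; the only single-point step among the measured compounds is a 6.6-fold higher number from compound 1 to compound 3 (0.82 log units; beyond the scatter). Compound 4 `Cc1nc(C)n(CC(=O)N2CCN(c3sc(C(F)(F)F)nc3-c3cnc(OC4CCC4)nc3)C[C@H]2C)n1` is not yet measured. From compound 3 it differs by cyclobutyl in place of methyl on an oxygen on an aromatic ring. Within the data shown here, no measured step touches this oxygen: compounds 1 and 2 do differ there, methoxy against ethoxy, but also in the group on the carbon bound to the carbonyl, and their values in this assay lie within the scatter of each other, so nothing can be drawn from that pair. Among the measured compounds shown here, with no step bearing on the change, the expectation for this assay is a number close to that of compound 3, with no step beyond the scatter in either direction. Compound 4 is therefore estimated at 900 nM, with a range of 350 nM to 2500 nM. The step this estimate means is a 1.2-fold lower number from compound 3 to compound 4 (0.06 log units; within the scatter), expected to stay within the scatter.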

Compound 4, half-maximal inhibitory concentration: 306 nM
Compound 4: middle estimate off by 2.9-fold (0.47 log units), on the high side, and the stated range ends above it.
By their numbers in this assay, from the lowest: compounds 1, 2 and 4 (each within the scatter of the next); then compound 3.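

Within the data shown here, this is the first single-point reading at the oxygen on the aromatic ring: in this assay, going from methoxy to cyclobutyloxy gives a 3.4-fold lower number from compound 3 to compound 4 (0.53 log units; beyond the scatter) and shows that the number at this place responds to the group on that oxygen. With the rest of compound 3 held constant, the four-membered carbon ring is accepted there and moves the number toward the stronger end, though this rests on one pair alone. Nothing measured here accounts for the size or direction of this step.

Going by these compounds, whether the same swap carries over to the other groups on the saturated chain carbon bound to the carbonyl remains open. Also open, on these data alone, is how an open chain such as butoxy, or an amine in place of the oxygen, would compare with cyclobutyloxy at this place.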